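Swapping the amine-bearing ring on the amide of compound 2

A few compounds are considered here, and "the series" means these few. Any claim that something is new, unique, unknown or untested is made for them only; others in the source may bear on it.

Of the compounds shown here, three share one core and have been tested in a functional assay on HEK293 cells for agonist activity at growth hormone secretagogue receptor type 1 (Homo sapiens), read by HTRF and inositol phosphate accumulation, with a stated time of 90 min, in the presence of a further agent that is not named here; a higher number here means a larger maximal response, a lower number a smaller maximal response. Compound 1 `O=C(N[C@H]1CN(S(=O)(=O)c2ccccc2)C[C@@H]1C(=O)N1C[C@H]2CCNC[C@H]21)c1cc(-c2ccccc2Cl)on1` gives 98%. Compound 2 `CN(C(=O)[C@H]1CN(S(=O)(=O)c2ccccc2)C[C@@H]1NC(=O)c1cc(-c2ccccc2Cl)on1)[C@H]1CCCNC1` gives 88%. Compound 3 `CN(C(=O)[C@H]1CN(S(=O)(=O)c2ccccc2)C[C@@H]1N(C)C(=O)c1cc(-c2ccccc2Cl)on1)[C@H]1CCCNC1` gives 95%. The three numbers sit close together: going from compound 1 to compound 2 there is a number 10 percentage points lower from compound 1 to compound 2 (within the scatter), and going from compound 2 to compound 3 there is a number 7 percentage points higher from compound 2 to compound 3 (within the scatter), so compound 2 is the point from which the other two are reached by steps that stay within the scatter.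

Compound 4 `CC(=O)N1CCC[C@H](NC(=O)[C@H]2CN(S(=O)(=O)c3ccccc3)C[C@@H]2NC(=O)c2cc(-c3ccccc3Cl)on2)C1` has not been measured. Compared with compound 2 the change is a group of 10 heavy atoms (7 carbon, 2 nitrogen, 1 oxygen; one six-membered non-aromatic ring with 1 hetero atom) in place of a group of 8 heavy atoms (6 carbon, 2 nitrogen; one six-membered non-aromatic ring with 1 hetero atom), on a carbonyl carbon. Among the measured compounds shown here, the step that bears on it most is the one from compound 1 to compound 2, where the group on the same carbonyl carbon was exchanged and the response barely moved. The methylation step from compound 2 to compound 3 also left the response where it was. For the measured compounds named here, nothing among the measured compounds points to a move beyond the scatter, so the expected step is a number 2 percentage points higher from compound 2 to compound 4 (within the scatter). Compound 4 is therefore estimated to give 90%, within a range from 75% to 100%.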

Compound 4, largest response reached (Emax), in percent of the reference or control that the assay uses: 91%
Compound 4: the middle estimate sits 1 percentage points below what was measured, within the range that was stated.
By their numbers in this assay, from the lowest: compounds 2, 4, 3 and 1 (each within the scatter of the next).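

In this assay, a larger group on this carbonyl carbon, with 10 heavy atoms including an oxygen and a double bond outside aromatic rings, gives a number 3 percentage points higher from compound 2 to compound 4 (within the scatter) and, against the group with two fused rings, a number 7 percentage points lower from compound 1 to compound 4 (within the scatter), so neither step leaves the scatter. Until now, the exchanges at this position had involved only groups of 8 heavy atoms made of carbon and nitrogen, whereas this result extends the tolerated set to a bigger group containing oxygen, with the same printed counts of hydrogen-bond donors and acceptors as the group it replaces. No measurement available here explains why the response stays within the scatter across these changes.

The compounds shown all carry a six-membered non-aromatic ring in the group on this carbonyl carbon, so it remains open whether an open chain, such as a longer alkyl amine, would keep the response within the scatter, and the same goes for a group bearing a carboxylic acid. The largest response also leaves open how much of each compound is needed to reach it.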